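Cell tolerance after swapping in a 1H-indazol-3-yl group

A few compounds are considered here, and "the series" means these few. Any claim that something is new, unique, unknown or untested is made for them only; others in the source may bear on it.

In an ADME assay on MT4 cells (Homo sapiens) for cytotoxicity, read by MTT assay (a lower number here means that less compound is tolerated, a higher number that more compound is tolerated), compound 1 (`Cc1cc(C)cc(S(=O)(=O)c2c(C(=O)NCC(=O)NC(C)c3ccccc3)[nH]c3ccc(Cl)cc23)c1`) gives 29400 nM and compound 2 (`Cc1cc(C)cc(S(=O)(=O)c2c(C(=O)NC(C)C(=O)NCCn3c(C)cnc3[N+](=O)[O-])[nH]c3ccc(Cl)cc23)c1`) gives 16000 nM as its reading. Compound 3 (`COc1cccc(F)c1CNC(=O)c1[nH]c2ccc(Cl)cc2c1S(=O)(=O)c1cc(C)cc(C)c1`) gives > 49900 nM as its result, and this is a limit of the assay, not a number. That places compound 3 at the limit of > 49900 nM in this assay, at which 1 of the 3 values shown sits, with no exact figure to start from.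

Compound 4 (`Cc1cc(C)cc(S(=O)(=O)c2c(C(=O)NCc3n[nH]c4ccccc34)[nH]c3ccc(Cl)cc23)c1`) differs from compound 3 by having 1H-indazol-3-yl in place of 2-fluoro-6-methoxyphenyl on a saturated chain carbon bound to an amide-type nitrogen. For the measured compounds named here, only one measured step changes this same place, namely an at least 1.6-fold higher number from compound 1 to compound 3 (0.22 log units; that floor lies within the scatter) and nothing larger has been seen there. On that single step, no change beyond the scatter is expected in this assay, and any visible move could only run downward from the limit. The estimated change is an at least 1.4-fold lower number from compound 3 to compound 4 (0.15 log units; that floor lies within the scatter) and it is expected to stay modest. Compound 4 is expected to read 35000 nM with an estimated range from 15000 nM to 50000 nM in this test.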

Compound 4, half-maximal cytotoxic concentration: > 50700 nM
Compound 4: only a limit was reported; the forecaster's own chance of this, stated with the estimate: 45%; at least 1.4-fold (0.16 log units) between middle value and limit.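

In this assay compound 4 gives > 50700 nM, which is a limit of the assay and not a number. At this place, on a saturated chain carbon bound to an amide-type nitrogen, 1H-indazol-3-yl thus ends at a limit just as 2-fluoro-6-methoxyphenyl does, even though it brings a hydrogen-bond donor that the other group lacks, and the step between these two compounds cannot be read. The only readable step is an at least 1.7-fold higher number from compound 1 to compound 4 (0.23 log units; that floor lies within the scatter), so this change has not yet been shown to move the reading beyond the scatter.

Going by these compounds, how much compound the cells would tolerate past the limits of compound 3 and compound 4 stays open, so the two groups cannot be ranked. On these data alone, it is also open whether a carboxylic acid or an amine on the same chain carbon would give an exact reading.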